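Taking one methoxy from compound 3

The compounds below may be only part of what the source reports. "The series", "measured", "known", "first", "only" and "open" are said of these compounds alone.

Values in a functional assay on M21 cells (Homo sapiens) for antiproliferative activity, read by sulforhodamine B assay, with a stated time of 48 h; a higher number here means a weaker inhibitor, a lower number a stronger inhibitor:
Compound 1 `CCCCN1CCN(c2ccc(S(=O)(=O)Oc3cccc(OC)c3)cc2)C1=O`: 30000 nM
Compound 2 `CCCCN1CCN(c2ccc(S(=O)(=O)Oc3cccc(F)c3)cc2)C1=O`: > 100000 nM, a limit
Compound 3 `CCCCN1CCN(c2ccc(S(=O)(=O)Oc3ccc(OC)c(OC)c3)cc2)C1=O`: > 100000 nM, a limit

Compound 3 stands at a limit and not at a number, > 100000 nM. Across the series so far, the record shows (the limit of > 100000 nM in this assay, at which 2 of the 3 values shown sit).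

Compound 4 `CCCCN1CCN(c2ccc(S(=O)(=O)Oc3ccc(OC)cc3)cc2)C1=O` differs from compound 3 by one change: hydrogen in place of methoxy on an aromatic carbon. Cut one bond further out, this reads 3,4-dimethoxyphenyl to 4-methoxyphenyl.

The closest measured step is an at least 3.3-fold higher number from compound 1 to compound 3 (0.52 log units; beyond the scatter), where a methoxy enters in place of hydrogen. Within the data shown here, the change to compound 4 also runs between one and two methoxy groups, but compound 4 keeps the other methoxy of compound 3, not the one kept in compound 1. Among the measured compounds shown here, compound 1 also gives an at least 3.3-fold higher number from compound 1 to compound 2 (0.52 log units; beyond the scatter), so the only readable number so far belongs to a compound with a single methoxy. The step that the two limits leave unreadable from compound 2 to compound 3 adds nothing on size.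

In this assay, a modest move to a lower number is therefore expected, with a real chance of no readable number at all. The estimated move is an at least 2.0-fold lower number from compound 3 to compound 4 (0.30 log units; that floor lies within the scatter). Compound 4 is expected at 50000 nM, with an estimated range of 15000 nM to 100000 nM.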

Compound 4, half-maximal inhibitory concentration: > 100000 nM
Compound 4: only a limit was reported; the forecaster's own chance of this, stated with the estimate: 50%; at least 2.0-fold (0.30 log units) between middle value and limit.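

In this assay compound 4 gives > 100000 nM, a limit and not a number, so taking away the methoxy ortho to a methoxy group does not by itself bring compound 3 to a readable value. Among these compounds, the methoxy left on the ring matters, as the remaining group in 4-methoxyphenyl does not match 3-methoxyphenyl: the series shows an at least 3.3-fold higher number from compound 1 to compound 4 (0.52 log units; beyond the scatter), and one methoxy alone is therefore not enough for a readable value, with compound 1 the only compound of the four to give one. The steps from compound 2 and from compound 3 to compound 4 cannot be read, as each joins two limits, and the series now sits mostly at one ceiling: the limit of > 100000 nM in this assay, at which 3 of the 4 values shown sit.

From the compounds shown here alone, how far compound 2, compound 3 and compound 4 lie past that limit stays open, so the size of the methoxy change on compound 3 stays open too. Also open, going by these compounds, is whether a hydroxy group, an ethoxy group or an amine in place of the methoxy of compound 1 would keep a readable value or lose it.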